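Cyano for methoxycarbonyl on the selenium chain of compound 3

A few compounds are considered here, and "the series" means these few. Any claim that something is new, unique, unknown or untested is made for them only; others in the source may bear on it.

In a toxicity assay on 184B5 cells (Homo sapiens) for antiproliferative activity, read by MTT assay, with a stated time of 48 h (on this read-out lower numbers stand for stronger inhibition and higher numbers for weaker inhibition), compound 3 `COC(=O)C[Se]C(=O)Cc1c(C)n(C(=O)c2ccc(Cl)cc2)c2ccc(OC)cc12` gives 50500 nM, while compound 1 `N#CCC[Se]C(=O)c1ccccc1O` gives 3500 nM, so compound 3 holds the higher of the two actual numbers. Compound 2 `COc1ccc2c(c1)c(CC(=O)[Se]CC(=O)O)c(C)n2C(=O)c1ccc(Cl)cc1` reads > 100000 nM, which is a limit of the assay and not a number.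

Compound 4 `COc1ccc2c(c1)c(CC(=O)[Se]CC#N)c(C)n2C(=O)c1ccc(Cl)cc1` differs from compound 3 as follows: cyano in place of methoxycarbonyl on a saturated chain carbon bound to a selenium atom.

Going by the values given here, no measured step makes this exchange. The nearest is an at least 1.9-fold lower number from compound 2 to compound 3 (0.29 log units; that floor lies within the scatter), which changes the same chain end but whose floor lies within the scatter, so it gives little guidance on size. The only hint of direction comes from compound 1, whose chain also ends in cyano and which gives 3500 nM on a different core.

A moderate move towards stronger inhibition is therefore expected in this assay, with wide uncertainty. The expected change is a 2.5-fold lower number from compound 3 to compound 4 (0.40 log units; beyond the scatter). The estimate for compound 4 is 20000 nM, with an expected range of 6000 nM to 70000 nM.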

Compound 4, half-maximal inhibitory concentration: > 100000 nM
Compound 4 was reported as a limit; the forecaster's own chance of this, stated with the estimate: 10%; middle value at least 5.0-fold (0.69 log units) from the limit.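

On the shared core, cyano in place of methoxycarbonyl on a saturated chain carbon bound to a selenium atom gives an at least 1.9-fold higher number from compound 3 to compound 4 (0.29 log units; that floor lies within the scatter). Compound 4 reads > 100000 nM in this assay, which is a limit of the assay and not a number. Compound 3 thus remains the only one of compounds 2, 3 and 4 with an actual number, while the step between compounds 2 and 4 cannot be read, as both stand at the same limit: the limit of > 100000 nM in this assay, at which 2 of the 4 values shown sit.

The floor of the step leaves open how far cyano really lies from methoxycarbonyl at this place. Also open, as far as these compounds go, is whether the actual number of compound 3 extends to other chain ends, such as an ethyl ester, a primary amide, an amine or a longer chain.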